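The compounds below may be only part of what the source reports. "The series", "measured", "known", "first", "only" and "open" are said of these compounds alone.

Compound 2 `COc1ccc2c(c1)/C(=C\c1c(OC)n(-c3ccccc3)c3ccccc13)C(=O)N2` gives 17400 nM in a functional assay on NSCLC cells (Homo sapiens) for cytotoxicity, with a stated time of 48 h (a higher number here means a weaker inhibitor of growth, a lower number a stronger inhibitor of growth), the second highest of the three numbers in hand. Compound 1 `COc1c(/C=C2/C(=O)Nc3ccc(Cl)cc32)c2ccccc2n1-c1ccccc1` gives 24600 nM in this assay, and compound 3 `COc1cc2c(/C=C3/C(=O)Nc4cccc(Cl)c43)c(Cl)n(Cc3cc(OC)c(OC)c(OC)c3)c2cc1C` gives 12000 nM; both sit within the scatter of compound 2, so no order among the three can be read from them.

Going by the values given here, the one step measured at a single position is the change from compound 1 to compound 2, a methoxy in place of chloro on an aromatic carbon, which gave a 1.4-fold lower number from compound 1 to compound 2 (0.15 log units; within the scatter), a shift that stays within the scatter.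

Compound 4 `COc1c(/C=C2/C(=O)Nc3ccccc32)c2ccccc2n1-c1ccccc1` differs from compound 2 by hydrogen in place of methoxy on an aromatic carbon. This touches the same aromatic carbon that the chloro-to-methoxy exchange touched without moving the number beyond the scatter, so the expected step from compound 2 to compound 4 is a 1.0-fold lower number from compound 2 to compound 4 (0.01 log units; within the scatter), no shift beyond the scatter in either direction. Compound 4 is accordingly estimated at 17000 nM in this assay, with a range from 7000 nM to 40000 nM.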

Compound 4, concentration for total growth inhibition: 8320 nM
Estimate against measurement, compound 4: 2.0-fold (0.31 log units) above, within the range that was stated.
By their numbers in this assay, from the lowest: compounds 4, 3, 2 and 1 (each within the scatter of the next, the first and the last beyond it).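

With hydrogen at this aromatic carbon, the position no longer looks indifferent to its substituent in this assay: removing the methoxy gives a 2.1-fold lower number from compound 2 to compound 4 (0.32 log units; beyond the scatter), and removing the chloro gives a 3.0-fold lower number from compound 1 to compound 4 (0.47 log units; beyond the scatter), both modest. The exchange of chloro for methoxy alone could not show this, since it stayed within the scatter (a 1.4-fold lower number from compound 1 to compound 2 (0.15 log units; within the scatter)), whereas both groups now go with a higher number than hydrogen on the shared core. No measurement on hand bears on why this number moves with either group.

Still open, on these data alone, is whether any group at this aromatic carbon can give a number lower than hydrogen does, for instance a fluoro, an amine or a carboxylic acid. Also open, as far as these compounds go, is whether the preference for hydrogen holds on a core carrying other groups, such as that of compound 3.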